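Amino for Nitro: One Change Repeated on Two Cores

This account rests on a few compounds, and the source may have more. Where it says the series, first, only, none or still open, it means among the compounds named here.

Measured so far in a functional assay on SGC-7901 cells (Homo sapiens) for antiproliferative activity, read by MTT assay, with a stated time of 72 h; on this read-out lower numbers stand for stronger inhibition and higher numbers for weaker inhibition:
compound 1, `COc1ccc(-c2ssc(=S)c2-c2cc(OC)c(OC)c(OC)c2)cc1[N+](=O)[O-]`: compound 1 gives 13600 nM
compound 2, `COc1ccc(-c2ssc(=S)c2-c2cc(OC)c(OC)c(OC)c2)cc1N`: compound 2 gives 444 nM
compound 3, `COc1ccc(-c2c(-c3cc(OC)c(OC)c(OC)c3)ssc2=O)cc1[N+](=O)[O-]`: compound 3 gives only a limit, > 100000 nM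

Compound 2 differs from compound 1 by amino in place of nitro on an aromatic carbon. That single change produced a 31-fold lower number from compound 1 to compound 2 (1.49 log units; beyond the scatter). For compound 3 the read-out is a limit and not a number; it sits at the limit of > 100000 nM in this assay, at which 1 of the 3 values shown sits. How the core of compound 3 differs from the core of compound 1 is not broken down here.

Compound 4, `COc1ccc(-c2c(-c3cc(OC)c(OC)c(OC)c3)ssc2=O)cc1N`, has not yet been measured. It differs from compound 3 by amino in place of nitro on an aromatic carbon. The surroundings of the changed carbon are described in the same words for both pairs, so this is the same change as that from compound 1 to compound 2, occurring twice among the compounds shown.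

Because the earlier step was a 31-fold lower number from compound 1 to compound 2 (1.49 log units; beyond the scatter), a step of similar size is expected here, namely an at least 10-fold lower number from compound 3 to compound 4 (1.00 log units; beyond the scatter). Since compound 3 is known only as a limit, the starting point is uncertain, and the estimate is correspondingly wide. Compound 4 is expected at 10000 nM, with a likely range from 2000 nM to 100000 nM, and it may itself be reported only as a limit.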

Compound 4, half-maximal inhibitory concentration: > 100000 nM
Compound 4 gave a limit, no number; the forecaster's own chance of this, stated with the estimate: 35%; middle value at least 10-fold (1.00 log units) from the limit.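

Compound 4, like compound 3, gives only a limit and not a number, so no step between these two compounds can be read: the limit of > 100000 nM in this assay, at which 2 of the 4 values shown sit.

The compounds shown leave open whether amino in place of nitro on an aromatic carbon changes the read-out at all on the core of compound 3, as it did on the core of compound 1.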